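The source may report more compounds than this note shows. Statements on the series, on what has been measured and on what is new or still open speak of the compounds shown alone.

Compound 1 `CCC(CC)c1ccc2c(NCCCNCc3cc(F)ccc3OC)ccnc2c1` and compound 2 `CCC(CC)c1ccc2c(NCCCNCc3ccco3)ccnc2c1` differ only in the group on a saturated chain carbon bound to an amine nitrogen, furan-2-yl in place of 5-fluoro-2-methoxyphenyl. In a physicochemical assay for acid dissociation, compound 1 gives 9.47 and compound 2 gives 9.47, a step of no change at the digits printed from compound 1 to compound 2 (within the scatter) within the scatter, so compound 1 stands level with compound 2. Compound 3 `COc1ccc(F)cc1CNCCCNc1ccnc2cc(Oc3ccccc3)ccc12` changes compound 1 at a different site: phenoxy in place of pentan-3-yl on an aromatic carbon. Among the compounds with values here, no measured step touches an aromatic carbon of the core, and the only known step was flat. No step beyond the scatter is therefore expected in this assay; compound 3 is estimated at 9.4, between 9 and 9.8, an expected step of a number 0.07 log units lower from compound 1 to compound 3 (within the scatter).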

Compound 3, acid dissociation constant: 9.28
For compound 3 the middle estimate is 0.12 log units above the measured one; measured number inside the range.
By their numbers in this assay, from the lowest: compounds 3, 1 and 2 (each within the scatter of the next).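

In this assay, phenoxy in place of pentan-3-yl on the aromatic carbon gives a number 0.19 log units lower from compound 1 to compound 3 (within the scatter) and so stays within the scatter. The earlier pair covered only the group on the saturated chain carbon, whereas this pair shows that a change on the shared core, bringing in an aromatic ring and an oxygen, also leaves the reading within the scatter. Nothing available explains this result. On these data alone, whether an amine or a carboxylic acid on this aromatic carbon would give a step beyond the scatter remains open. So does the outcome of a longer chain in the side chain.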